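Swapping the azetidine attachment point on the carbonyl carbon

This account rests on a few compounds, and the source may have more. Where it says the series, first, only, none or still open, it means among the compounds named here.

Among the measured compounds shown here, compound 2 `Cc1ccccc1C(=O)Nc1ccc(S(=O)(=O)NC2CCN(C(=O)C3CNC3)CC2)c2ccccc12` is the one whose value stands lowest among the two single numbers in an assay on L1.2 cells for binding affinity to C-C chemokine receptor type 8 (Homo sapiens); a lower number here means a stronger inhibitor, a higher number a weaker inhibitor: compound 2 gives 1.5 nM. Its nearest neighbour is compound 1 `Cc1ccccc1C(=O)Nc1ccc(S(=O)(=O)NC2CCN(C(=O)CCCCN)CC2)c2ccccc12`, which in this assay gives 199 nM. The third compound, compound 3 `Cc1ccccc1C(=O)Nc1ccc(S(=O)(=O)NC2CCN(C(=O)[C@@H]3CCCN3)CC2)c2ccccc12`, has several entries in this assay rather than one number: compound 3 gives 0.7 nM; 1 nM (2 entries), as seen in the several entries of compound 3 in this assay, 0.7 nM; 1 nM (2 entries), and these sit close to the value of compound 2.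

For the measured compounds named here, the only step measured between two single numbers is a 130-fold lower number from compound 1 to compound 2 (2.12 log units; beyond the scatter), a large gain when a four-membered ring replaced a chain on the carbonyl carbon.

Compound 4 `Cc1ccccc1C(=O)Nc1ccc(S(=O)(=O)NC2CCN(C(=O)N3CCC3)CC2)c2ccccc12` has not been measured. It differs from compound 2 in one place: azetidin-1-yl in place of azetidin-3-yl on a carbonyl carbon. The same atoms are kept, but the ring now sits on the carbonyl through its nitrogen, and the hydrogen-bond donor counted in compound 2 is no longer there. Going by the values given here, compounds 1, 2 and 3 all carry such a donor, so no measured step shows what its loss does; the measured step only shows how much the ring itself mattered. With the donor gone, compound 4 is expected to bind more weakly than compound 2, the expected step being a 20-fold higher number from compound 2 to compound 4 (1.30 log units; beyond the scatter). In this assay compound 4 is estimated at 30 nM, within a range of 5 nM to 300 nM.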

Compound 4, inhibition constant: 3.5 nM
Compound 4: the middle estimate sits 8.6-fold (0.93 log units) above what was measured; measured number below the stated range.
By their numbers in this assay, from the lowest: compound 2; then compound 4; then compound 1.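

Joining the ring to the carbonyl carbon through its nitrogen rather than through a ring carbon gives a 2.3-fold higher number from compound 2 to compound 4 (0.37 log units; beyond the scatter) in this assay, a modest change even though azetidin-1-yl counts 0 hydrogen-bond donors and azetidin-3-yl counts 1. Against the open chain, the same ring gives a 57-fold lower number from compound 1 to compound 4 (1.75 log units; beyond the scatter) in this assay, so compound 4 keeps most of the large gain seen with compound 2. Compound 1 carries a hydrogen-bond donor on its 4-aminobutyl group and compound 4 carries none at this position, yet compound 4 has the far lower number, so among compounds 1, 2 and 4 the donor count alone does not set the level of binding, and a donor in this group is not needed for a low number.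

Still open, from the compounds shown here alone, is whether a larger ring joined through its nitrogen, such as piperidin-1-yl, or an open-chain group such as dimethylamino on the same carbonyl carbon, would hold this level. Nothing measured here explains why the four-membered ring does so much better than the chain or why losing the donor costs so little.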